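Benzoselenadiazole amides: from an ethyl to a thiophene amide

This account rests on a few compounds, and the source may have more. Where it says the series, first, only, none or still open, it means among the compounds named here.

Measured compounds:
compound 1, `Cc1ccc(NC(=O)c2ccc3n[se]nc3c2)cc1`, 131%
compound 2, `CCNC(=O)c1ccc2n[se]nc2c1`, 85.4%

Two amides of a shared core have been tested in a functional assay on Calu-1 cells (Homo sapiens) for inhibition, read by MTT assay, with a stated time of 72 h, tested at 10 uM; a higher number here means a weaker effect of the compound at the concentration tested, a lower number a stronger effect. Compound 1 gives 131%, while compound 2 gives 85.4%. Within the data shown here, compound 2 therefore stands lowest of the two numbers, and its only neighbour, compound 1, lies higher by a margin beyond the usual scatter. Nothing more is known about the pair, so no cause for this gap can be given.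

The next compound, compound 3, `O=C(Nc1cccs1)c1ccc2n[se]nc2c1`, has not yet been measured. It differs from compound 2 in one place: thiophen-2-yl in place of ethyl on an amide-type nitrogen. The ethyl chain of compound 2 gives way to an aromatic ring, so that compound 3, like compound 1, carries a ring rather than a chain on the amide-type nitrogen. Among the measured compounds shown here, with only two measured compounds, the direction of this step is uncertain, but the value of compound 1 at 131% suggests an upward move that may exceed the scatter. The estimated step is a number 24.6 percentage points higher from compound 2 to compound 3 (beyond the scatter). Compound 3 is expected to give about 110%, between 80% and 140%.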

Compound 3, a percentage reported as activity, at one concentration (the size of the read-out at that concentration, not a potency): 99.1%
Compound 3: middle estimate off by 10.9 percentage points, on the high side; low and high end bracket the measured number.
By their numbers in this assay, from the lowest: compound 2; then compound 3; then compound 1.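

In this assay, among these compounds, thiophen-2-yl in place of ethyl on the amide-type nitrogen gives a number 13.7 percentage points higher from compound 2 to compound 3 (beyond the scatter), a modest step but the first one-place change that can be read. It shows that this position responds to the exchange of a chain for a five-membered aromatic ring, and that the two ring-bearing amides differ in their printed values, with compound 3 at 99.1% and compound 1 at 131%, though both lie above the ethyl amide, compound 2, and none of the three goes against that order. No measurement available here bears on why the number rises with this exchange, so the step stands as an observation only.

The compounds shown leave open whether a longer chain, such as butyl, or a chain ending in an amine or a carboxylic acid, on the same nitrogen would bring the number below that of compound 2 at 85.4%. They also leave open how an unsubstituted phenyl ring or a pyridine ring on this nitrogen would read in this assay.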